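This account rests on a few compounds, and the source may have more. Where it says the series, first, only, none or still open, it means among the compounds named here.

Working notes on the series. Among the measured compounds shown here, in a functional assay (Homo sapiens) for inhibition (a higher number here means a weaker inhibitor, a lower number a stronger inhibitor), compound 1 (`CSc1ccc(CSc2nc(-c3ccc(F)cc3)c(-c3ccncc3)[nH]2)cc1`) gives 670 nM and stands lowest of the three numbers measured so far. Compound 2 (`CSc1ccc(CSc2nc(-c3ccc(Br)cc3)c(-c3ccncc3)[nH]2)cc1`) gives 2400 nM in the same read-out, and compound 3 (`CSc1ccc(CSc2nc(-c3ccccc3)c(-c3ccncc3)[nH]2)cc1`) gives 72500 nM there. The measured changes all fall on one aromatic carbon: bromo in place of fluoro gives a 3.6-fold higher number from compound 1 to compound 2 (0.55 log units; beyond the scatter) and hydrogen in place of fluoro gives a 110-fold higher number from compound 1 to compound 3 (2.03 log units; beyond the scatter) while hydrogen in place of bromo gives a 30-fold higher number from compound 2 to compound 3 (1.48 log units; beyond the scatter) as well.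

Compound 4 (`Oc1ccccc1CSc1nc(-c2ccc(F)cc2)c(-c2ccncc2)[nH]1`) keeps the fluoro group of compound 1 and differs elsewhere: 2-hydroxyphenyl in place of 4-(methylsulfanyl)phenyl on a saturated chain carbon bound to a sulfur on the saturated chain carbon bound to a sulfur. For the measured compounds named here, no measured step covers this place. Going by the values given here, the steps above show only that one small change can move the number a long way, so the margin has to stay wide. A modest rise in the number is expected, and a large one cannot be excluded. The expected move is a 1.9-fold higher number from compound 1 to compound 4 (0.29 log units; within the scatter) in this assay on this reasoning. Compound 4 is estimated at 1300 nM with an expected range from 250 nM to 7000 nM in this read-out.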

Compound 4, half-maximal inhibitory concentration: 440 nM
For compound 4 the middle estimate is 3.0-fold (0.47 log units) above the measured one; the measured number falls inside the stated range.
By their numbers in this assay, from the lowest: compounds 4 and 1 (each within the scatter of the next); then compound 2; then compound 3.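

In this assay, 2-hydroxyphenyl in place of 4-(methylsulfanyl)phenyl on a saturated chain carbon bound to a sulfur gives a 1.5-fold lower number from compound 1 to compound 4 (0.18 log units; within the scatter). Among the compounds shown here, the earlier steps covered only one aromatic carbon, so this is the first reading at this position: here the whole 4-(methylsulfanyl)phenyl group, with its sulfur, can be exchanged without a move beyond the scatter, and the entering group brings a hydrogen-bond donor that the leaving group lacks. No measurement is available that accounts for this outcome.

Open, as far as these compounds go, is whether a plain phenyl, an amine, a carboxylic acid or a longer chain on that carbon would also stay within the scatter of compound 1. Also open, from the compounds shown here alone, is whether the same exchange would hold with the bromo group of compound 2 or the hydrogen of compound 3.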